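Amino in place of nitro in compound 3

The compounds below may be only part of what the source reports. "The series", "measured", "known", "first", "only" and "open" are said of these compounds alone.

In a functional assay on HT-29 cells (Homo sapiens) for inhibition (on this read-out lower numbers stand for stronger inhibition and higher numbers for weaker inhibition), compound 3 `COc1ccc(/C=C\c2ccc3ccccc3c2)cc1[N+](=O)[O-]` gives 3280 nM and compound 1 `FC(F)(F)Oc1cccc(/C=C\c2ccc3ccccc3c2)c1` gives 3500 nM within the usual scatter of it. Compound 2 `COc1ccc(/C=C/c2ccc3ccccc3c2)cc1[N+](=O)[O-]` reaches only a limit of this assay (> 5000 nM). Compound 4 `COc1ccc(/C=C\c2ccc3ccccc3c2)cc1N` carries amino in place of nitro on an aromatic carbon, ortho to a methoxy group (amino in place of nitro on an aromatic carbon). For the measured compounds named here, the only measured step (an at least 1.5-fold lower number from compound 2 to compound 3 (0.18 log units; that floor lies within the scatter)) comes with the fact that compounds 2 and 3 differ only in the configuration as drawn and does not touch this exchange. Going by the values given here, no measured step gives the size of the exchange, so only a modest move to a lower number is expected, and that expectation is held loosely. The expected step (a 2.2-fold lower number from compound 3 to compound 4 (0.34 log units; beyond the scatter)) is an estimate with wide uncertainty. For compound 4 the expected value is 1500 nM in an estimated range from 200 nM to 6000 nM overall.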

Compound 4, half-maximal inhibitory concentration: 1820 nM
The estimate for compound 4 lay 1.2-fold (0.08 log units) below the measured number; measured number inside the range.
By their numbers in this assay, from the lowest: compounds 4, 3 and 1 (each within the scatter of the next). At a limit, above all of these: compound 2.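

In this assay, amino in place of nitro on an aromatic carbon, ortho to a methoxy group, gives a 1.8-fold lower number from compound 3 to compound 4 (0.26 log units; within the scatter). At this place, then, the nitro group is not needed to hold a number of this size: one heavy atom can stand for three, and a hydrogen-bond donor can enter, without a change beyond the scatter. Nothing at hand bears on why the exchange leaves the number there.

As far as these compounds go, what a hydroxyl group or an acetamide would give at this place stays open. So does how the amino compound behaves with its double bond drawn E.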